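Amino in Place of Hydrogen: from Compound 1 to Compound 4

The compounds below may be only part of what the source reports. "The series", "measured", "known", "first", "only" and "open" are said of these compounds alone.

Compound 1 `O=C(O)Cc1sc(C(c2ccc(F)cc2)c2ccc(F)cc2)nc1-c1ccnc(F)c1` gives the lowest number of the three measured compounds in an in vitro assay on HEK385-7 cells for displacement of a labelled ligand from prostaglandin D2 receptor 2 (Homo sapiens) (a higher number here means a weaker inhibitor, a lower number a stronger inhibitor), namely 0.48 nM. Compound 3 `O=C(O)Cc1sc(C(c2ccccc2)c2ccc(F)cc2)nc1-c1ccc(Cl)cc1` gives 17 nM, and compound 2 `O=C(O)Cc1sc(C(c2ccccc2)c2ccc(Cl)cc2)nc1-c1ccc(Cl)cc1` gives 45 nM. Among the measured compounds shown here, the only single-point step among the measured compounds, a 2.6-fold lower number from compound 2 to compound 3 (0.42 log units; beyond the scatter), concerns a fluoro in place of chloro and does not bear on the change considered here. Compound 4 `Nc1cc(-c2nc(C(c3ccc(F)cc3)c3ccc(F)cc3)sc2CC(=O)O)cc(F)n1` differs from compound 1 by amino in place of hydrogen on an aromatic carbon. For the measured compounds named here, since no measured step addresses an amino group, the expectation rests on compound 1 alone, and a step not beyond the scatter is expected, a 1.5-fold higher number from compound 1 to compound 4 (0.16 log units; within the scatter). Compound 4 is therefore estimated at 0.7 nM in this assay, within a range of 0.2 nM to 3 nM.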

Compound 4, half-maximal inhibitory concentration: 220 nM
The estimate for compound 4 lay 310-fold (2.50 log units) below the measured number; the whole stated range lies below it.
By their numbers in this assay, from the lowest: compound 1; then compound 3; then compound 2; then compound 4.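

In this assay, amino in place of hydrogen next to the ring nitrogen gives a 460-fold higher number from compound 1 to compound 4 (2.66 log units; beyond the scatter). Among the compounds shown here, this shows that the position is far from indifferent to substitution: turning 2-fluoropyridin-4-yl into 2-amino-6-fluoropyridin-4-yl is enough to lose most of the strength of compound 1, a sensitivity that the earlier compounds, none of which changes this ring, could not reveal.

Going by these compounds, whether a methyl, a hydroxyl or a methylamino group at this place would fare any better remains open. Nothing measured here gives the reason for this large step.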